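Compound 3 to compound 4: an aryl swap

The compounds below may be only part of what the source reports. "The series", "measured", "known", "first", "only" and "open" are said of these compounds alone.

Measured so far in a functional assay on A549 cells (Homo sapiens) for antiproliferative activity, read by MTT assay, with a stated time of 72 h; a higher number here means a weaker inhibitor, a lower number a stronger inhibitor
Compound 1 `COc1cc(C(=O)c2sc3ccccc3c2-c2ccc(F)cc2)cc(OC)c1OC` gives 3200 nM
Compound 2 `COc1ccc(-c2c(C(=O)c3cc(OC)c(OC)c(OC)c3)sc3ccccc23)cc1` gives 4400 nM
Compound 3 `COc1cc(C(=O)c2sc3ccccc3c2-c2ccc(SC)cc2)cc(OC)c1OC` gives 5400 nM

Compound 3 sits within the scatter of both other compounds, with a 1.2-fold higher number from compound 2 to compound 3 (0.09 log units; within the scatter) and a 1.7-fold higher number from compound 1 to compound 3 (0.23 log units; within the scatter) on record. Compound 4 `COc1ccc(OC)c(-c2c(C(=O)c3cc(OC)c(OC)c(OC)c3)sc3ccccc23)c1` carries 2,5-dimethoxyphenyl in place of 4-(methylsulfanyl)phenyl on an aromatic carbon of the shared core (2,5-dimethoxyphenyl in place of 4-(methylsulfanyl)phenyl on an aromatic carbon). The closest evidence comes from single-group swaps on that same aryl group. Methoxy in place of fluoro gave a 1.4-fold higher number from compound 1 to compound 2 (0.14 log units; within the scatter) and no measured step leaves the scatter. Among the compounds with values here, none of the measured compounds carries the 2,5-dimethoxyphenyl group, however, so this change is larger than anything the steps have sampled. No step beyond the scatter is therefore expected in this assay and the data favour no clear direction, although the range is kept wide, more so on the upper side. The expected change is a 1.1-fold higher number from compound 3 to compound 4 (0.05 log units; within the scatter) on this estimate. Compound 4 is estimated at 6000 nM (expected range 2000 nM to 18000 nM).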

Compound 4, half-maximal inhibitory concentration: > 10000 nM
Compound 4 gave a limit, no number (the forecaster's own chance of this, stated with the estimate: 10%); at least 1.6-fold (0.22 log units) between middle value and limit.
By their numbers in this assay, from the lowest: compounds 1, 2 and 3 (each within the scatter of the next). At a limit, above all of these: compound 4.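

In this assay compound 4 stands at a limit and gives no number: the limit of > 10000 nM in this assay, at which 1 of the 4 values shown sits.

Among the aryl groups at this position, 2,5-dimethoxyphenyl gives the first steps beyond the scatter, with an at least 2.2-fold higher number from compound 2 to compound 4 (0.35 log units; beyond the scatter) and an at least 3.1-fold higher number from compound 1 to compound 4 (0.49 log units; beyond the scatter). The comparison with 4-(methylsulfanyl)phenyl is less firm, with an at least 1.8-fold higher number from compound 3 to compound 4 (0.26 log units; that floor lies within the scatter), so the floor alone does not separate that pair.

How far compound 4 lies past its limit remains open, as does which of the two methoxy groups of 2,5-dimethoxyphenyl accounts for the steps beyond the scatter. Also open, on these data alone, is how an aryl group at this position carrying an amine or a carboxylic acid would read in this assay.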